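A few compounds are considered here, and "the series" means these few. Any claim that something is new, unique, unknown or untested is made for them only; others in the source may bear on it.

Measured so far in an ADME assay on Vero cells (Chlorocebus sabaeus) for cytotoxicity, with a stated time of 7 days; a higher number here means that more compound is tolerated, a lower number that less compound is tolerated:
- compound 1 `COc1ccc2[nH]c(C(=O)N3CC(=O)N(c4ccccc4)[C@@H](Cc4ccccc4)C3)cc2c1`: > 30000 nM.
- compound 2 `COc1ccc2[nH]c(C(=O)N3CC(=O)N(Cc4ccccc4)[C@@H](Cc4ccccn4)C3)cc2c1`: > 30000 nM.
- compound 3 `COc1ccc2[nH]c(C(=O)N3CC(=O)N(Cc4cccc(OC(F)F)c4)[C@@H](CN4CCCCC4)C3)cc2c1`: 12100 nM.

For compound 1 the value in this assay is a limit of the assay, not a number. For compound 2 the value in this assay is likewise a limit and not a number. Compound 3 alone gives a number in this assay. Compound 2 thus stands at the limit shared by two of the three values, and the limit of > 30000 nM in this assay, at which 2 of the 3 values shown sit, marks where most of the series sits.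

Going by the values given here, no pair of measured compounds differs in one place, so no measured step is available. The unmeasured compound 4 `COc1ccc2[nH]c(C(=O)N3CC(=O)N(Cc4ccccc4)[C@@H](CN4CC5CC5C4)C3)cc2c1` differs from compound 2 as follows: a group of 6 heavy atoms (5 carbon, 1 nitrogen; one three-membered non-aromatic ring of carbon only, one five-membered non-aromatic ring with 1 hetero atom) in place of a group of 6 heavy atoms (5 carbon, 1 nitrogen; one six-membered aromatic ring with 1 hetero atom), on a saturated chain carbon bound to a saturated ring carbon. Compound 3 carries a saturated nitrogen ring on the same position and gives 12100 nM; compound 4 carries a saturated nitrogen ring as well. The step from compound 2 to compound 4 in this assay is expected to be small, likely none beyond the scatter, and an at least 1.2-fold lower number from compound 2 to compound 4 (0.07 log units; that floor lies within the scatter) states that expectation. For compound 4 the estimate in this assay is 25000 nM, with a range from 10000 nM to 60000 nM, and a limit rather than a number is about as likely as not.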

Compound 4, half-maximal cytotoxic concentration: 13800 nM
Compound 4: the middle estimate sits 1.8-fold (0.26 log units) above what was measured; the measured number falls inside the stated range.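

In this assay, the position on a saturated chain carbon bound to a saturated ring carbon now has its first readable step. Putting the group with a three-membered carbon ring and a five-membered nitrogen ring in place of pyridin-2-yl gives an at least 2.1-fold lower number from compound 2 to compound 4 (0.33 log units; beyond the scatter), so this position is not silent to the change. Compound 2 carries a limit and not a number, which makes the printed step a floor and leaves its full size unknown: the limit of > 30000 nM in this assay, at which 2 of the 4 values shown sit.

One step does not separate the departure of the aromatic ring from the arrival of the saturated nitrogen ring. Also open, on these data alone, is how an open-chain amine such as dimethylamino, or a carboxylic acid, on this same position would read in this assay.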